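Cyclohexyl for propyl at the limit of the assay

The source may report more compounds than this note shows. Statements on the series, on what has been measured and on what is new or still open speak of the compounds shown alone.

Measured so far in an ADME assay on Caco-2 cells (Homo sapiens) for inhibition, read by sulforhodamine B assay, with a stated time of 72 h; a lower number here means a stronger inhibitor, a higher number a weaker inhibitor:
- compound 1 `CCCNC(=C\C(=O)/C=C/c1ccc(O)c(OC)c1)/C=C/c1ccc(O)c(OC)c1`: > 25000 nM
- compound 2 `COc1cc(/C=C/C(=O)CC(=O)/C=C/c2ccc(OC(C)=O)c(OC)c2)ccc1OC(C)=O`: > 25000 nM

Compound 1 stands at the edge of the measurable range: its > 25000 nM is a limit and not a number. Compound 2 gives > 25000 nM, which is also a limit. Among the compounds with values here, the series so far therefore offers only (the limit of > 25000 nM in this assay, at which 2 of the 2 values shown sit).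

The next compound to be read is compound 3 `COc1cc(/C=C/C(=O)/C=C(/C=C/c2ccc(O)c(OC)c2)NC2CCCCC2)ccc1O`. It keeps the core of compound 1 but has cyclohexyl in place of propyl on an amine nitrogen. Within the data shown here, no step between measured compounds is available to size this change, and neither measured compound has a numerical value in this assay.

No shift beyond the scatter is expected in this assay, and a further reading at the limit is the likeliest outcome. The estimated step is a number no higher from compound 1 to compound 3 (the limit leaves the size open). If a number is reported, the expected value for compound 3 is 25000 nM, with an estimated range from 10000 nM to 50000 nM.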

Compound 3, half-maximal inhibitory concentration: > 25000 nM
Compound 3 gave a limit, no number (the forecaster's own chance of this, stated with the estimate: 65%); the middle value sits exactly at the limit.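

In this assay compound 3 gives > 25000 nM, which is a limit and not a number. Compound 1 also stands at a limit, so no step can be read between compound 1 and compound 3. The compounds shown leave open how cyclohexyl and propyl on the amine nitrogen compare in this assay, and the series gives no numerical value to work from: the limit of > 25000 nM in this assay, at which 3 of the 3 values shown sit.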